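An Amino Group Enters the Shared Core

A few compounds are considered here, and "the series" means these few. Any claim that something is new, unique, unknown or untested is made for them only; others in the source may bear on it.

Compound 1 `ClCc1ccc(Cn2cnc3c(Cl)ncnc32)cc1`: 3460 nM
Compound 2 `ClCc1cccc(Cn2cnc3c(Cl)nc(Cl)nc32)c1`: 3380 nM

In a functional assay on LOX IMVI cells (Homo sapiens) for cytotoxicity, read by sulforhodamine B assay, with a stated time of 48 h (a lower number here means a stronger inhibitor of growth, a higher number a weaker inhibitor of growth), compound 1 gives 3460 nM, the higher of the two numbers, yet compound 2 with 3380 nM sits within the scatter of it, so no order between them can be drawn. Compound 3 `Nc1nc(Cl)c2ncn(Cc3ccc(CCl)cc3)c2n1` differs from compound 1 by amino in place of hydrogen on an aromatic carbon. Going by the values given here, no measured pair shows this change, so its effect is unknown; the expectation is a small step in this assay, if any, not clearly beyond the scatter in either direction. Compound 3 is estimated at 3000 nM, with a range from 1000 nM to 9000 nM, which means an expected step of a 1.2-fold lower number from compound 1 to compound 3 (0.06 log units; within the scatter).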

Compound 3, concentration for total growth inhibition: 43700 nM
Compound 3: middle estimate off by 15-fold (1.16 log units), on the low side, and the stated range ends below it.
By their numbers in this assay, from the lowest: compounds 2 and 1 (each within the scatter of the next); then compound 3.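

In this assay, amino in place of hydrogen on the aromatic carbon between two ring nitrogen atoms gives a 13-fold higher number from compound 1 to compound 3 (1.10 log units; beyond the scatter) and so a large loss of growth inhibition. Going by these compounds alone, compound 1 and compound 2 offered no readable step at this position, so this is the first sign that the position is sensitive to change. No evidence here bears on why the number rises.

From the compounds shown here alone, it remains open whether a methyl, a hydroxyl or a methylamino group on this carbon would bring a step of similar size.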